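The compounds below may be only part of what the source reports. "The series", "measured", "known", "first", "only" and "open" are said of these compounds alone.

Among the measured compounds shown here, in an assay on isolated protein for inhibition of alkaline phosphatase, tissue-nonspecific isozyme (Bos taurus), read by chemiluminescence and spectrophotometry (on this read-out higher numbers stand for weaker inhibition and lower numbers for stronger inhibition), three compounds have numbers so far. Compound 1 `NS(=O)(=O)c1ccc(NC(=O)c2ccccc2)cc1` gives 16600 nM, and compound 2 `NS(=O)(=O)c1cccc(NC(=O)c2ccc(F)cc2)c1` gives 16200 nM. Compound 3 `Cc1ccc(S(=O)(=O)Nc2ccc(S(N)(=O)=O)cc2)cc1` gives 91900 nM, the highest of the three numbers; compound 1 is its nearest, with a gap beyond the scatter, and compound 2 lies slightly further off. Compound 4 `NS(=O)(=O)c1ccc(NS(=O)(=O)c2ccc(F)cc2)cc1` has not yet been measured. It differs from compound 3 by fluoro in place of methyl on an aromatic carbon, which one bond further out reads 4-methylphenyl to 4-fluorophenyl. For the measured compounds named here, no pair among the measured compounds differs in one place only, so no step of this kind is known. Swapping methyl for fluoro is expected to move the number little, perhaps slightly downward, not clearly beyond the scatter. The expected step is a 1.3-fold lower number from compound 3 to compound 4 (0.12 log units; within the scatter). For compound 4 in this assay the estimate is 70000 nM, between 25000 nM and 200000 nM.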

Compound 4, inhibition constant: 1390 nM
Estimate against measurement, compound 4: 50-fold (1.70 log units) above; measured number outside the range, below it.
By their numbers in this assay, from the lowest: compound 4; then compounds 2 and 1 (each within the scatter of the next); then compound 3.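

On an aromatic carbon para to a large group, this single-atom exchange is far from neutral: fluoro in place of methyl gives a 66-fold lower number from compound 3 to compound 4 (1.82 log units; beyond the scatter). Among the compounds shown here, the earlier compounds held no pair differing in one place, so this is the first evidence that this position strongly affects the number. Nothing available bears on why the step is so large.

From the compounds shown here alone, whether chloro, methoxy or plain hydrogen at this position would read like fluoro or like methyl stays open. So does whether the same exchange would matter in the amide-linked compounds, such as compound 1.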